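Biaryl replacement of cyclohexyl in the benzylamide series

This account rests on a few compounds, and the source may have more. Where it says the series, first, only, none or still open, it means among the compounds named here.

Compound 1 `CC(C)CCSc1cc(C(F)(F)F)ccc1CNC(=O)C(C)c1ccc(NS(C)(=O)=O)c(F)c1` and compound 2 `CC(C(=O)NCc1ccc(C(F)(F)F)cc1C1CCCCC1)c1ccc(NS(C)(=O)=O)c(F)c1` share the amide core and differ only at one aromatic carbon. In an assay on CHO cells for antagonist activity at transient receptor potential cation channel subfamily V member 1 (Homo sapiens), read by FLIPR (a higher number here means a weaker inhibitor, a lower number a stronger inhibitor), compound 1 gives 1.4 nM, and compound 2 gives 0.6 nM. Within the data shown here, the single measured step, a 2.3-fold lower number from compound 1 to compound 2 (0.37 log units; beyond the scatter), was a cyclohexyl in place of an isopentylsulfanyl group. Among the measured compounds shown here, on these two numbers compound 2 stands at the lowest value, with compound 1 the only neighbour.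

Compound 3 `CC(C(=O)NCc1ccc(C(F)(F)F)cc1-c1ccc(C(C)(C)C)cc1)c1ccc(NS(C)(=O)=O)c(F)c1` is not yet measured. It differs from compound 2 in one place: 4-(tert-butyl)phenyl in place of cyclohexyl on an aromatic carbon. For the measured compounds named here, no measured step describes this exchange; the one step known, from compound 1 to compound 2, concerns a different pair of groups at the same carbon and was modest in size. It gives no direction for a cyclohexyl to aromatic swap, so the expectation in this assay is a step of no more than the usual scatter, in either direction.

The expected value of compound 3 in this assay is 0.8 nM, with a range from 0.25 nM to 2.5 nM, corresponding to an expected step of a 1.3-fold higher number from compound 2 to compound 3 (0.12 log units; within the scatter).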

Compound 3, inhibition constant: 1.1 nM
Compound 3: middle estimate off by 1.4-fold (0.14 log units), on the low side, within the range that was stated.
By their numbers in this assay, from the lowest: compounds 2, 3 and 1 (each within the scatter of the next, the first and the last beyond it).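

At the aromatic carbon meta to the trifluoromethyl group, this assay accepts an aromatic ring as well as a saturated one: 4-(tert-butyl)phenyl, with 10 heavy atoms against 6 for cyclohexyl, comes to a 1.8-fold higher number from compound 2 to compound 3 (0.26 log units; within the scatter). Against isopentylsulfanyl the same group comes to a 1.3-fold lower number from compound 1 to compound 3 (0.10 log units; within the scatter), so compound 3 cannot be separated from either of the other two, even though the earlier exchange, a 2.3-fold lower number from compound 1 to compound 2 (0.37 log units; beyond the scatter), lies beyond the scatter. No available evidence accounts for this result.

Open, from the compounds shown here alone, is whether the tert-butyl group of compound 3 contributes anything at this carbon: a plain phenyl ring, or a phenyl ring carrying an amine or a carboxylic acid in place of the tert-butyl group, would separate the effect of the ring from that of its substituent. Also open is whether a pyridine or a morpholine ring at the same carbon would stay in the same range in this assay, since the three groups shown here, for all their differences in size and ring type, contain no nitrogen or oxygen.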